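The source may hold more compounds than are shown below. What is called first, only, known or untested is meant among the compounds shown, and "the series" means these compounds.

Measured set:
- compound 1, `CCCCC(N)c1cc(C(F)(F)F)ccc1N1CCN(C(=O)CCc2ccc(Cl)cc2Cl)CC1`: 190 nM
- compound 2, `CC[C@H](C)C(N)c1cc(C(F)(F)F)ccc1N1CCN(C(=O)CCc2ccc(Cl)cc2Cl)CC1`: 75 nM
- compound 3, `CCN[C@H](c1cc(C(F)(F)F)ccc1N1CCN(C(=O)CCc2ccc(Cl)cc2Cl)CC1)C(C)CC`: 92 nM

In an assay on HEK293 cells for displacement of a labelled ligand from Melanocortin receptor 4 (Homo sapiens) (a lower number here means a stronger inhibitor, a higher number a weaker inhibitor), compound 3 holds the second highest of the three numbers. Its nearest neighbour is compound 2, the gap being a 1.2-fold higher number from compound 2 to compound 3 (0.09 log units; within the scatter), and the furthest is compound 1, with a 2.1-fold lower number from compound 1 to compound 3 (0.31 log units; beyond the scatter).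

Compound 4, `CCC(C)[C@H](NCc1ccccc1F)c1cc(C(F)(F)F)ccc1N1CCN(C(=O)CCc2ccc(Cl)cc2Cl)CC1`, is not yet measured. It differs from compound 3 thus: 2-fluorophenyl in place of methyl on a saturated chain carbon bound to an amine nitrogen.

Going by the values given here, of the measured steps, only a 1.2-fold higher number from compound 2 to compound 3 (0.09 log units; within the scatter) touches the amine substituent, and it stayed within the scatter; no step covers 2-fluorophenyl in place of methyl at this place. The step of a 2.5-fold lower number from compound 1 to compound 2 (0.40 log units; beyond the scatter) concerns the chain instead. The expectation for compound 4 in this assay is therefore a step of a 1.0-fold lower number from compound 3 to compound 4 (0.01 log units; within the scatter), most likely within the scatter, with a wide range.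

Compound 4 is estimated at 90 nM, between 30 nM and 300 nM.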

Compound 4, inhibition constant: > 10000 nM
Compound 4: no number, only a limit; the forecaster's own chance of this, stated with the estimate: 3%; at least 110-fold (2.04 log units) between middle value and limit.
By their numbers in this assay, from the lowest: compounds 2 and 3 (each within the scatter of the next); then compound 1. At a limit, above all of these: compound 4.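

In this assay, the step of a 1.2-fold higher number from compound 2 to compound 3 (0.09 log units; within the scatter) suggested that an ethyl group on the amine nitrogen is accommodated, but that does not extend to the larger 2-fluorobenzyl group: an at least 100-fold higher number from compound 3 to compound 4 (2.03 log units; beyond the scatter). This gives the series its first sharp boundary at this position, one that the chain change in a 2.5-fold lower number from compound 1 to compound 2 (0.40 log units; beyond the scatter) gave no sign of. The value for compound 4 is a limit, not a number: the limit of > 10000 nM in this assay, at which 1 of the 4 values shown sits.

The shown compounds do not separate the contribution of the aromatic ring from that of the fluorine. Unsubstituted benzyl, propyl and cyclohexylmethyl groups on the amine would help to locate the boundary between ethyl and 2-fluorobenzyl.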